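The source may report more compounds than this note shows. Statements on the series, on what has been measured and on what is new or still open speak of the compounds shown alone.

Measured compounds:
- compound 1, `CN(C(=O)c1ccc(Cl)cc1)c1ccc2[nH]c(-c3n[nH]c4ccccc34)cc2n1`: 3000 nM
- compound 2, `CN(C(=O)c1ccccc1)c1ccc2[nH]c(-c3n[nH]c4cc(Cl)ccc34)cc2n1`: 13100 nM
- compound 3, `CN(C(=O)c1ccccc1)c1ccc2[nH]c(-c3n[nH]c4cc(C#N)ccc34)cc2n1`: 24000 nM

All three were tested in a functional assay on HCT-116 cells (Homo sapiens) for antiproliferative activity, read by MTT assay, with a stated time of 72 h; a higher number here means a weaker inhibitor, a lower number a stronger inhibitor. Compound 1 stands at the lowest of the three numbers; compound 2 sits beyond the scatter above it, and compound 3 further still. Compounds 2 and 3 carry a plain benzoyl on the shared core and differ only in the group on the fused ring of the other half; that step, chloro to cyano, gave a 1.8-fold higher number from compound 2 to compound 3 (0.26 log units; within the scatter), so the two values cannot be told apart.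

Compound 4, `Cc1ccc(S(=O)(=O)N(C)c2ccc3[nH]c(-c4n[nH]c5ccccc45)cc3n2)cc1`, keeps the core and the unsubstituted fused ring of compound 1 but changes the group on the ring nitrogen: (4-methylphenyl)sulfonyl in place of (4-chlorophenyl)carbonyl on a nitrogen on an aromatic ring. Within the data shown here, no measured step bears on this change: the one step in hand concerns a different ring and a different pair of groups, and it was within the scatter. Carbonyl to sulfonyl is therefore an open question here, with no direction given by the data.

Lacking any guide, the expectation for compound 4 is a number near that of compound 1, with a wide range, as a 1.7-fold higher number from compound 1 to compound 4 (0.22 log units; within the scatter). Compound 4 is estimated at 5000 nM, between 1500 nM and 20000 nM.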

Compound 4, half-maximal inhibitory concentration: 13300 nM
The estimate for compound 4 lay 2.7-fold (0.42 log units) below the measured number, within the range that was stated.
By their numbers in this assay, from the lowest: compound 1; then compounds 2, 4 and 3 (each within the scatter of the next).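

In this assay, the group on a nitrogen on an aromatic ring now has its first measured step, and that step clears the scatter: a 4.4-fold higher number from compound 1 to compound 4 (0.65 log units; beyond the scatter), with (4-methylphenyl)sulfonyl in place of (4-chlorophenyl)carbonyl. Among these compounds, the only earlier step, a 1.8-fold higher number from compound 2 to compound 3 (0.26 log units; within the scatter), concerned a different ring, so compound 4 is the first sign that the number in this assay responds to what is attached at this nitrogen. Nothing measured on these compounds accounts for the shift.

As far as these compounds go, this swap changes two things at once, carbonyl to sulfonyl and chloro to methyl, so the part each plays remains open, and a (4-chlorophenyl)sulfonyl or a (4-methylphenyl)carbonyl group at the same nitrogen would separate them. Also open, from the compounds shown here alone, is how the number would respond to an acetyl group, which has no aromatic ring, or to a benzoyl group carrying a carboxylic acid.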